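The compounds below may be only part of what the source reports. "The series", "measured", "known", "first", "only" and "open" are said of these compounds alone.

Compound 2 `CCCCC(CC)n1ccc2cc(/C(C)=C/C(=O)Nc3ccccc3OCCCC(=O)O)ccc21` is the starting point. In an assay on Prostate gland for inhibition of steroid 5-alpha-reductase (Rattus norvegicus) (a lower number here means a stronger inhibitor, a higher number a weaker inhibitor), compound 2 gives 7.1 nM. For the measured compounds named here, the only other measured compound, compound 1 `CCCC(CC)n1ccc2cc(/C(C)=C/C(=O)Nc3ccccc3OCCCC(=O)O)ccc21`, gives 9.3 nM in this assay. Compound 2 stands next to compound 1 on these two numbers, since the step of a 1.3-fold lower number from compound 1 to compound 2 (0.12 log units; within the scatter) lies within the scatter, so the two cannot be told apart with confidence.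

Compound 3 `CCCCCC(CCCCC)n1ccc2cc(/C(C)=C/C(=O)Nc3ccccc3OCCCC(=O)O)ccc21` has not yet been measured. It differs from compound 2 in one place: 1-pentylhexyl in place of 1-ethylpentyl on an aromatic nitrogen. Going by the values given here, only the step of a 1.3-fold lower number from compound 1 to compound 2 (0.12 log units; within the scatter) bears on this move. That step also lengthened the chain on the aromatic nitrogen, and it was small. The present change is larger in its count of carbon atoms, so that measured step is only a rough guide, and the uncertainty is wide. The expectation is no step beyond the scatter in this assay; the estimated step is a 1.0-fold lower number from compound 2 to compound 3 (0.01 log units; within the scatter). Compound 3 is therefore expected to give about 7 nM in this assay, within an estimated range from 2 nM to 30 nM.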

Compound 3, half-maximal inhibitory concentration: 25 nM
The estimate for compound 3 lay 3.6-fold (0.55 log units) below the measured number, and the stated range covers the measured number.
By their numbers in this assay, from the lowest: compounds 2 and 1 (each within the scatter of the next); then compound 3.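

Lengthening the chain on the aromatic nitrogen does not stay free of cost in this assay: the change to 1-pentylhexyl gives a 3.5-fold higher number from compound 2 to compound 3 (0.55 log units; beyond the scatter) and is the first change at this position to lie beyond the scatter. The comparison with the shorter 1-ethylbutyl group points the same way, with a 2.7-fold higher number from compound 1 to compound 3 (0.43 log units; beyond the scatter) on the same scale. So the two smaller groups, which cannot be told apart, both sit on the lower side of 1-pentylhexyl, and this position accepts a small change in chain size without a readable shift, while the larger change costs a modest amount of inhibition.

As far as these compounds go, it remains open whether length or shape matters here, and a straight hexyl chain or a cyclohexyl ring on the aromatic nitrogen would help to separate the two. Nothing available accounts for the rise in the number.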